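The source may hold more compounds than are shown below. What is called first, only, known or untested is meant among the compounds shown, and "the series" means these compounds.

Measured compounds:
compound 1, `COc1ccc2ccc(=O)oc2c1-c1cc(-c2ccc(C)cc2)nc(N)n1`, 932000 nM; 1070000 nM (2 entries) in a functional assay on aorta (Rattus norvegicus, strain Wistar) for inhibition; on this read-out lower numbers stand for stronger inhibition and higher numbers for weaker inhibition
compound 2, `COc1ccc2ccc(=O)oc2c1-c1cc(-c2ccc(C(F)(F)F)cc2)nc(N)n1`, 1060000 nM in this assay

Compound 2 stands on a single number in this assay, 1060000 nM; a further entry for compound 2 carries no single number. Among the compounds with values here, compound 1, the only other compound with a number, gives 932000 nM; 1070000 nM (2 entries) in this assay, and its repeated entries the several entries of compound 1 in this assay, 932000 nM; 1070000 nM (2 entries) lie within the usual scatter of one another and of the value of compound 2. Within the data shown here, no step between two measured compounds that differ in one place is available, so there is no measured step to lean on.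

Compound 3, `COc1ccc2ccc(=O)oc2c1-c1cc(-c2ccc([N+](=O)[O-])cc2)nc(N)n1`, differs from compound 2 in one place: nitro in place of trifluoromethyl on an aromatic carbon. Among the measured compounds shown here, with only two measured compounds, both at very weak inhibition and within the scatter of each other, the step from trifluoromethyl to nitro is expected to fall within the scatter, with no clear direction; the expected step is a 1.1-fold lower number from compound 2 to compound 3 (0.03 log units; within the scatter). Compound 3 is therefore estimated at 1000000 nM in this assay, within a range of 450000 nM to 2500000 nM.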

Compound 3, half-maximal inhibitory concentration: "not active" (no number reported)
Compound 3 has no reported number here, and the estimate cannot be compared.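

In this assay, within the data shown here, compound 3 is reported only as "not active", without a number, so no step from compound 2 to compound 3 can be read. The compounds shown leave open whether any group at this place on the shared core moves inhibition beyond the spread seen in the repeated readings: the several entries of compound 1 in this assay, 932000 nM; 1070000 nM (2 entries)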